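This account rests on a few compounds, and the source may have more. Where it says the series, first, only, none or still open, it means among the compounds named here.

Measured compounds:
compound 1 `N#Cc1ccccc1Cc1cnc(CCc2ccc(-c3ccccc3C(=O)O)cc2)[nH]1` — 642 nM
compound 2 `CCCCc1cnc(CCCc2ccc(-c3ccccc3C(=O)O)cc2)[nH]1` — 382 nM
compound 3 `CCCCc1cnc(C(Cc2ccc(-c3ccccc3C(=O)O)cc2)C(C)C)[nH]1` — 2240 nM

All three were read in an in vitro functional assay on cells for agonist activity at Bombesin receptor subtype-3 (Mus musculus), read by luminescence and calcium flux; on this read-out lower numbers stand for an effect already at smaller amounts and higher numbers for an effect only at larger amounts of compound. Compound 1 sits with the second highest of the three numbers. Compound 2 is nearest to it, and the two differ by less than the scatter of repeated runs, so no order can be set on that pair. Compound 3 lies furthest away, with a higher number than compound 1 by more than the scatter. Compounds 2 and 3 carry a different group on the shared core and a different linker from compound 1, so neither speaks to the change taken up here.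

Compound 4 `O=C(O)c1ccccc1-c1ccc(CCc2ncc(Cc3cccc(F)c3F)[nH]2)cc1` has not been measured. It differs from compound 1 in one place: 2,3-difluorophenyl in place of 2-cyanophenyl on a saturated chain carbon bound to an aromatic carbon. Going by the values given here, no measured pair shows this change, so there is no step to lean on. In this assay the step of a 1.2-fold lower number from compound 1 to compound 4 (0.07 log units; within the scatter) is expected to be small, none beyond the scatter, in either direction. Compound 4 is therefore estimated at 550 nM, with a range of 150 nM to 2000 nM.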

Compound 4, half-maximal effective concentration: 8 nM
Estimate against measurement, compound 4: 69-fold (1.84 log units) above; the whole stated range lies above it.
By their numbers in this assay, from the lowest: compound 4; then compounds 2 and 1 (each within the scatter of the next); then compound 3.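

In this assay the group on a saturated chain carbon bound to an aromatic carbon proves far from neutral: 2,3-difluorophenyl in place of 2-cyanophenyl gives an 80-fold lower number from compound 1 to compound 4 (1.90 log units; beyond the scatter) with the rest of the molecule unchanged, a step beyond the scatter. The exchange keeps the eight heavy atoms and the six-membered aromatic ring of carbon only, yet it removes the triple bond and the hydrogen-bond acceptor and brings in two fluorine atoms, so the substitution on this ring alone is enough to move the read-out this far. No measured property of either group bears on the step, and no cause can be assigned to it.

From the compounds shown here alone, whether a plain phenyl, a 2-fluorophenyl or a 3-fluorophenyl at this place would give a similar number stays open. Also open, going by these compounds, is whether the step carries over to a longer chain between the core and the biphenyl acid part.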